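The source may hold more compounds than are shown below. What is called first, only, known or untested is meant among the compounds shown, and "the series" means these compounds.

Two compounds carry the shared core seen in compound 1 `COc1cc(/C=C/C(=O)c2c(C)[n+]([O-])c3ccccc3[n+]2[O-])cc(OC)c1OC` and compound 2 `Cc1c(C(=O)/C=C/c2ccc(Br)cc2)[n+]([O-])c2ccccc2[n+]1[O-]`. In an ADME assay on HPLF cells (Homo sapiens) for cytotoxicity, with a stated time of 48 h (a higher number here means that more compound is tolerated, a lower number that less compound is tolerated), compound 1 gives 33000 nM, and in this assay compound 2 gives 26000 nM. Compound 2 has the lowest of the two numbers, yet its gap to compound 1 is within the scatter, so the two values cannot be ordered.

Compound 3 `Cc1ccc(/C=C/C(=O)c2c(C)[n+]([O-])c3ccccc3[n+]2[O-])cc1` follows from compound 2 by one change: methyl in place of bromo on an aromatic carbon. Going by the values given here, no step between measured compounds shows the effect of this exchange, so any expectation rests on the narrow spread of compounds 1 and 2 alone. Compound 3 is expected to stay close to compound 2, with a step of a 1.1-fold higher number from compound 2 to compound 3 (0.03 log units; within the scatter) that is not beyond the scatter in either direction. On that basis compound 3 is estimated at 28000 nM in this assay, with a range from 14000 nM to 56000 nM.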

Compound 3, half-maximal cytotoxic concentration: 23000 nM
Beside the measured number, compound 3's estimate is 1.2-fold (0.09 log units) above it, and the stated range covers the measured number.
By their numbers in this assay, from the lowest: compounds 3, 2 and 1 (each within the scatter of the next).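

In this assay, going by these compounds alone, the exchange of 4-bromophenyl for 4-methylphenyl gives a 1.1-fold lower number from compound 2 to compound 3 (0.05 log units; within the scatter), the first direct reading of a single change at this position. On an aromatic carbon para to a large group, methyl and bromo therefore cannot be told apart in this read-out, so this one exchange leaves the tolerated concentration within the scatter. Nothing available explains this outcome.

The compounds shown leave open whether a group of another kind at the same place, such as an amine or a carboxylic acid, would give a step beyond the scatter. They also leave open whether methyl in place of bromo would give the same result with a longer chain or a further ring on the shared core.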